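From phenyl to 4-chlorophenyl: one step, one number

A few compounds are considered here, and "the series" means these few. Any claim that something is new, unique, unknown or untested is made for them only; others in the source may bear on it.

compound 1 `CC(=O)SCC(=O)c1ccc(NCc2ccc(OC(F)(F)F)cc2)cc1`: "not determined" (no result reported)
compound 2 `CC(=O)SCC(=O)c1ccc(C(=O)Nc2ccc(OC(F)(F)F)cc2)cc1`: "not determined" (no result reported)
compound 3 `CC(=O)SCC(=O)c1ccc(NS(=O)(=O)c2ccccc2)cc1`: 15400 nM

Among the measured compounds shown here, in a functional assay on HCT-116 cells (Homo sapiens) for cytotoxicity (on this read-out lower numbers stand for an effect already at smaller amounts and higher numbers for an effect only at larger amounts of compound), compound 3 gives 15400 nM, the only number available, as neither compound 1 nor compound 2 has a reported result. Its standing relative to those two therefore cannot be judged. Compound 4 `CC(=O)SCC(=O)c1ccc(NS(=O)(=O)c2ccc(Cl)cc2)cc1` differs from compound 3 by one change, phenyl to 4-chlorophenyl: chloro in place of hydrogen on an aromatic carbon, para to a large group (chloro in place of hydrogen on an aromatic carbon). For the measured compounds named here, no measured step shows what such a change does here, so the expectation rests on compound 3 at 15400 nM alone. The expected change is a 1.7-fold lower number from compound 3 to compound 4 (0.23 log units; within the scatter), a small move toward lower numbers that would stay within the scatter. For compound 4 the estimated value is 9000 nM, with an expected range from 3000 nM to 26000 nM.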

Compound 4, half-maximal effective concentration: 30800 nM
Compound 4: middle estimate off by 3.4-fold (0.53 log units), on the low side; the measured number lies above the stated range.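

Among the compounds shown here, the change from phenyl to 4-chlorophenyl brings a 2.0-fold higher number from compound 3 to compound 4 (0.30 log units; within the scatter) in this assay and so gives the first readable step. At this place, para to a large group, chloro in place of hydrogen leaves compound 4 and compound 3 within the usual scatter of each other. Nothing available explains this reading. As far as these compounds go, whether an amine, a methoxy group or a carboxylic acid in the same place would separate from compound 3 stays open. So does whether chloro would read the same on the cores of compound 1 and compound 2.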